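The source may hold more compounds than are shown below. What is called first, only, known or untested is meant among the compounds shown, and "the series" means these compounds.

Compound 1 `CSc1ccccc1Nc1nc2c(Nc3ccc(C(F)(F)F)cc3)ncnc2s1` gives 43 nM in a functional assay on HEK293 cells for antagonist activity at transient receptor potential cation channel subfamily V member 1 (Homo sapiens), read by calcium flux; a higher number here means a weaker inhibitor, a lower number a stronger inhibitor.
Compound 2 `CS(=O)(=O)c1ccccc1Nc1nc2c(Nc3ccc(C(F)(F)F)cc3)ncnc2s1` gives 234 nM in this assay.
Compound 3 `CSc1nc(Nc2ccc(C(F)(F)F)c(Cl)c2)c2nc(Nc3c(Cl)cccc3Cl)sc2n1` gives 224 nM in this assay.

Compound 1 and compound 2 share one core and differ only by methylsulfonyl in place of methylsulfanyl on an aromatic carbon; that single change gave a 5.4-fold higher number from compound 1 to compound 2 (0.74 log units; beyond the scatter). Compound 3 has a different core, and the difference between the two cores is not broken down here. Compound 4 `CS(=O)(=O)c1nc(Nc2ccc(C(F)(F)F)c(Cl)c2)c2nc(Nc3c(Cl)cccc3Cl)sc2n1` has not yet been measured; it is made from compound 3 by methylsulfonyl in place of methylsulfanyl on an aromatic carbon. For the measured compounds named here, this is the same kind of change as the one from compound 1 to compound 2, but not the same: there the place was on a six-membered aromatic ring of carbon only, ortho to a large group, whereas here it is on a six-membered aromatic ring with 2 nitrogen, between two ring nitrogen atoms, within a fused system. Since the surroundings differ, the step is expected to be of roughly the size seen with compound 1 and compound 2, a 5.4-fold higher number from compound 1 to compound 2 (0.74 log units; beyond the scatter), but with wider uncertainty: a 4.5-fold higher number from compound 3 to compound 4 (0.65 log units; beyond the scatter) is expected. Compound 4 is therefore estimated at 1000 nM, between 280 nM and 3600 nM.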

Compound 4, half-maximal inhibitory concentration: 274 nM
Beside the measured number, compound 4's estimate is 3.6-fold (0.56 log units) above it; measured number below the stated range.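

In this assay, methylsulfonyl in place of methylsulfanyl gave a 1.2-fold higher number from compound 3 to compound 4 (0.09 log units; within the scatter), so on this core the swap leaves no readable mark on the number. The swap therefore does not carry over from one core to the other at the same size: the same change on two cores in this assay, a 5.4-fold higher number (0.74 log units; beyond the scatter) from compound 1 to compound 2 and a 1.2-fold higher number (0.09 log units; within the scatter) from compound 3 to compound 4, 4.4-fold (0.65 log units) apart, beyond the scatter of two such steps. For the compounds shown here, with only one pair on each core, this shows that the size of the step need not hold from core to core, but it does not show which of the differences between the two cores accounts for the gap.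

The compounds shown leave open whether another group on the same aromatic carbon, between two ring nitrogen atoms, such as an amine, a methoxy group or a longer chain, would give a number clearly apart from those of compound 3 and compound 4. They also leave open whether the swap on a further core would resemble the pair of compound 1 and compound 2 or the pair of compound 3 and compound 4.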